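From Methoxy to Methyl on an Aromatic Carbon

A few compounds are considered here, and "the series" means these few. Any claim that something is new, unique, unknown or untested is made for them only; others in the source may bear on it.

Compounds measured in a functional assay on K562 cells (Homo sapiens) for antiproliferative activity, read by MTT assay, with a stated time of 5 days; a higher number here means a weaker inhibitor, a lower number a stronger inhibitor:
compound 1 `COc1ccc(C=C(C(=O)c2cc(OC)c(OC)c(OC)c2)c2ccccc2O)cc1O`: 35000 nM
compound 2 `COc1ccc(C(=Cc2ccc(OC)c(O)c2)C(=O)c2cc(OC)c(OC)c(OC)c2)cc1`: 12000 nM

For the measured compounds named here, of the two compounds measured so far, compound 2 has the lower number at 12000 nM, and compound 1 the higher at 35000 nM. The next compound to be tested is compound 3 `COc1ccc(C=C(C(=O)c2cc(OC)c(OC)c(OC)c2)c2ccc(C)cc2)cc1O`. It differs from compound 2 by methyl in place of methoxy on an aromatic carbon, para to a large group: methyl in place of methoxy on an aromatic carbon.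

Going by the values given here, only one measured step bears on this change: a 2.9-fold lower number from compound 1 to compound 2 (0.46 log units; beyond the scatter). That modest step put 4-methoxyphenyl in place of 2-hydroxyphenyl, so it touches the same substituent position only loosely. Among the compounds with values here, no measured pair compares methoxy with methyl directly. The data therefore give no direction for the change, and no shift beyond the scatter is expected in this assay. The expected step is a 1.1-fold higher number from compound 2 to compound 3 (0.03 log units; within the scatter), a small estimated change. For compound 3 the estimated value is 13000 nM, with an expected range from 4500 nM to 35000 nM.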

Compound 3, half-maximal inhibitory concentration: 32000 nM
The estimate for compound 3 lay 2.5-fold (0.39 log units) below the measured number, within the range that was stated.
By their numbers in this assay, from the lowest: compound 2; then compounds 3 and 1 (each within the scatter of the next).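

The step of a 2.7-fold higher number from compound 2 to compound 3 (0.43 log units; beyond the scatter) in this assay shows that this change is not silent: exchanging 4-methoxyphenyl for 4-methylphenyl moves the number by about as much as the earlier step of a 2.9-fold lower number from compound 1 to compound 2 (0.46 log units; beyond the scatter) did, and in the opposite direction. The second new step, a 1.1-fold lower number from compound 1 to compound 3 (0.04 log units; within the scatter), shows that 4-methylphenyl and 2-hydroxyphenyl on this chain carbon cannot be told apart in these measurements, so among the three compounds only the 4-methoxyphenyl group of compound 2 stands clear of the other two. What links the methoxy group to the lower number remains unexplained, as nothing at hand speaks to the cause.

The three compounds do not show whether it is the oxygen of the methoxy group or the group as a whole that counts, and an ethoxy group, a hydroxyl or an amine on the same aromatic carbon would be needed to separate these readings. From the compounds shown here alone, it also remains open whether methyl in place of methoxy would give a step of the same size on a core carrying other groups.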